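Chloro in Place of Fluoro: Expectation for Compound 4

The compounds below may be only part of what the source reports. "The series", "measured", "known", "first", "only" and "open" are said of these compounds alone.

Of the compounds shown here, three built on one shared core have been measured in an assay for inhibition of Alpha amylase (Homo sapiens), with a stated time of 10 min; on this read-out higher numbers stand for weaker inhibition and lower numbers for stronger inhibition. Compound 1 `COc1cc(Br)c(-c2nc3ccccc3[nH]2)cc1OC` gives 1510 nM. Compound 2 `Oc1ccc(-c2nc3cc(F)ccc3[nH]2)c(O)c1`, which carries two hydroxyl groups and no bromo, gives 2980 nM. Compound 3 `COc1cc(Br)c(-c2nc3cc(F)ccc3[nH]2)cc1OC`, the starting point here, gives 1570 nM. Compound 3 thus holds the second highest of the three numbers: its nearest neighbour is compound 1, reached by the step of a 1.0-fold higher number from compound 1 to compound 3 (0.02 log units; within the scatter), and its furthest is compound 2, whose number sits within the scatter of that of compound 3, so no order among the three can be claimed.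

Compound 4 `COc1cc(Br)c(-c2nc3cc(Cl)ccc3[nH]2)cc1OC` is obtained from compound 3 by chloro in place of fluoro on an aromatic carbon, on an aromatic carbon of a six-membered aromatic ring of carbon only, part of a fused system of two rings. Going by the values given here, the only measured step that bears on this position is a 1.0-fold higher number from compound 1 to compound 3 (0.02 log units; within the scatter), where fluoro entered in place of hydrogen and the number did not move beyond the scatter. With no other change at this site on record, the exchange of one halogen for another is expected to leave this assay essentially unchanged. The expected step is a 1.0-fold lower number from compound 3 to compound 4 (0.02 log units; within the scatter). Compound 4 is therefore estimated at 1500 nM, within a range from 700 nM to 3500 nM.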

Compound 4, half-maximal inhibitory concentration: 1730 nM
For compound 4 the middle estimate is 1.2-fold (0.06 log units) below the measured one; low and high end bracket the measured number.
By their numbers in this assay, from the lowest: compounds 1, 3, 4 and 2 (each within the scatter of the next).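

In this assay, chloro in place of fluoro on this aromatic carbon gives a 1.1-fold higher number from compound 3 to compound 4 (0.04 log units; within the scatter), and chloro in place of hydrogen at the same carbon gives a 1.1-fold higher number from compound 1 to compound 4 (0.06 log units; within the scatter). Where the earlier compounds covered only hydrogen and fluoro at this carbon, a second halogen now shows the same lack of any readable change, so hydrogen, fluoro and chloro cannot be told apart here on the background of compound 1. No supporting data bear on why these exchanges leave the number within the scatter.

The compounds shown leave open whether a group that is not a halogen, such as an amine, a carboxylic acid or a longer chain, would move the number beyond the scatter at this position, since only hydrogen and two halogens have been seen there. From the compounds shown here alone, it also remains open whether chloro in place of fluoro would stay within the scatter when the other aromatic ring carries the two hydroxyl groups of compound 2 rather than the bromo and methoxy groups of compound 3.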